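This account rests on a few compounds, and the source may have more. Where it says the series, first, only, none or still open, it means among the compounds named here.

Measured compounds:
Compound 1 `N#CC1=C(N)Oc2c(c3nc4ccccc4nc3c3ccccc23)C12C(=O)N(Cc1cnnn1-c1ccccc1Cl)c1ccccc12`: in a functional assay on A549 cells (Homo sapiens) for antiproliferative activity, read by MTT assay, with a stated time of 48 h (on this read-out higher numbers stand for weaker inhibition and lower numbers for stronger inhibition), compound 1 gives 42600 nM.
Compound 2 `COc1ccc(-n2nncc2CN2C(=O)C3(C(C#N)=C(N)Oc4c3c3nc5ccccc5nc3c3ccccc43)c3ccccc32)cc1`: in this assay compound 2 reaches only the assay limit, > 50000 nM.
Compound 3 `CCOc1ccccc1-n1nncc1CN1C(=O)C2(C(C#N)=C(N)Oc3c2c2nc4ccccc4nc2c2ccccc32)c2ccccc21`: in this assay compound 3 likewise sits at the limit, > 50000 nM.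

Compound 3 thus has no number of its own in this assay, only a limit; it shares that standing with compound 2, as noted in the limit of > 50000 nM in this assay, at which 2 of the 3 values shown sit, while compound 1 alone gives a readable number. The step from compound 3 to compound 4 `CC(=O)Nc1ccc(-n2nncc2CN2C(=O)C3(C(C#N)=C(N)Oc4c3c3nc5ccccc5nc3c3ccccc43)c3ccccc32)cc1` is 4-acetamidophenyl in place of 2-ethoxyphenyl on an aromatic nitrogen. Bearing on it are the earlier changes on the same aromatic nitrogen: an at least 1.1-fold higher number from compound 1 to compound 3 (0.06 log units; that floor lies within the scatter), an at least 1.1-fold higher number from compound 1 to compound 2 (0.06 log units; that floor lies within the scatter), and a step that the two limits leave unreadable from compound 2 to compound 3. None of these separates one aryl group from another beyond the scatter, and two of the three compounds sit at the limit. Compound 4 is therefore expected to stay at or close to that limit in this assay, with a step that the limit leaves unreadable from compound 3 to compound 4 as the expected step. The estimate for compound 4 is 55000 nM, with a range from 25000 nM to 120000 nM.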

Compound 4, half-maximal inhibitory concentration: > 50000 nM
Compound 4: no number, only a limit (the forecaster's own chance of this, stated with the estimate: 65%); the middle value lies beyond the limit too.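

In this assay compound 4 gives only a limit, > 50000 nM, so an aryl group carrying a hydrogen-bond donor, which the 2-ethoxyphenyl group lacks, does not bring a readable number at this aromatic nitrogen. Against the 2-chlorophenyl group the change gives an at least 1.1-fold higher number from compound 1 to compound 4 (0.06 log units; that floor lies within the scatter), while the steps to compound 4 from compound 2 and from compound 3 cannot be read. The limit now holds for most of this small set: the limit of > 50000 nM in this assay, at which 3 of the 4 values shown sit.

As far as these compounds go, how far compound 2, compound 3 and compound 4 lie beyond the limit stays unknown, so these three aryl groups cannot be ranked. Also open, from the compounds shown here alone, is whether an amine or a carboxylic acid on the phenyl ring, or a longer chain in its place, would give a readable number.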